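Ethynyl on the cyclopropyl: what compound 4 is expected to tolerate

The compounds below may be only part of what the source reports. "The series", "measured", "known", "first", "only" and "open" are said of these compounds alone.

Three macrocyclic acylsulfonamides have been measured in an ADME assay on cells (Homo sapiens) for activation; a higher number here means that more compound is tolerated, a lower number that less compound is tolerated:

compound 1, `CCn1cc(-c2cc(OCC[C@@H]3NC(=O)N(C)CCCC/C=C\[C@@H]4C[C@@]4(C(=O)NS(=O)(=O)C4(C)CC4)NC3=O)c3ccc(OC)c(C)c3n2)cn1`, gives 36700 nM
compound 2, `COc1ccc2c(OCC[C@@H]3NC(=O)N(C)CCCC/C=C\[C@@H]4C[C@@]4(C(=O)NS(=O)(=O)C4CC4)NC3=O)cc(-c3nc(C(C)C)cs3)nc2c1Cl`, gives 40400 nM
compound 3, `COc1ccc2c(OCC[C@@H]3NC(=O)N(C)CCCC/C=C\[C@@H]4C[C@@]4(C(=O)NS(=O)(=O)C4(C)CC4)NC3=O)cc(-c3nc(C(C)C)cs3)nc2c1Br`, gives 28300 nM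

The three numbers sit close together. The value of compound 2 is not separated from that of compound 1 or that of compound 3 beyond the usual scatter of this assay, so the three compounds are tolerated to a similar degree and no ranking among them is supported by the data. Going by the values given here, no pair of measured compounds differs in only one place, so no single structural step has yet been paired with a measured effect.

Compound 4, `C#CC1(S(=O)(=O)NC(=O)[C@@]23C[C@H]2/C=C\CCCCN(C)C(=O)N[C@@H](CCOc2cc(-c4nc(C(C)C)cs4)nc4c(Cl)c(OC)ccc24)C(=O)N3)CC1`, differs from compound 2 in one place: ethynyl in place of hydrogen on a saturated ring carbon. All else in the two structures is the same. Among the compounds with values here, with no measured step of this kind available, the expectation rests on the narrow band the three measured compounds occupy. Compound 4 is expected to give about 36000 nM, with a range from 20000 nM to 65000 nM. This estimate means an expected step of a 1.1-fold lower number from compound 2 to compound 4 (0.05 log units; within the scatter), which is no change beyond the scatter.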

Compound 4, half-maximal cytotoxic concentration: 26300 nM
Compound 4: middle estimate off by 1.4-fold (0.14 log units), on the high side, and the stated range covers the measured number.
By their numbers in this assay, from the lowest: compounds 4, 3, 1 and 2 (each within the scatter of the next).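

Going by these compounds alone, the change from cyclopropyl to 1-ethynylcyclopropyl gives the first step in this set that can be read at a single place: in this assay it amounts to a 1.5-fold lower number from compound 2 to compound 4 (0.19 log units; within the scatter). Ethynyl in place of hydrogen on this saturated ring carbon, which adds 2 heavy atoms, therefore leaves the tolerated concentration within the scatter. Nothing measured here speaks to why the step is so small.

On these data alone, whether an amine, a carboxylic acid or a longer chain on this saturated ring carbon would also stay within the scatter remains open. Also open, as far as these compounds go, is how ethynyl would compare with the methyl that compound 1 and compound 3 carry on that ring; each of them differs from compound 4 in more than one place.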